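Cyclic amine variation on the quinoline amide series

The compounds below may be only part of what the source reports. "The series", "measured", "known", "first", "only" and "open" are said of these compounds alone.

Measured compounds:
- compound 1 `CN(c1ccc2cc(NC(=O)CCc3ccc(C(F)(F)F)cc3)ccc2n1)C1CCCCC1` — 1200 nM
- compound 2 `CN(c1ccc2cc(NC(=O)CCc3ccc(C(F)(F)F)cc3)ccc2n1)C1CCCC1` — 350 nM
- compound 3 `O=C(CCc1ccc(C(F)(F)F)cc1)Nc1ccc2nc(N3CC4CCC3CC4)ccc2c1` — 190 nM

In a functional assay on HEK293 cells for activation of melanin-concentrating hormone receptor 1 (Rattus norvegicus), read by inositol phosphate accumulation (a lower number here means that less compound is needed, a higher number that more compound is needed for the effect), compound 3 gives the lowest of the three numbers. Its nearest neighbour is compound 2, which differs by a step that lies within the scatter, so the two cannot be ordered; compound 1 stands furthest away, and the step of a 6.3-fold lower number from compound 1 to compound 3 (0.80 log units; beyond the scatter) is beyond the scatter.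

Compound 4 `O=C(CCc1ccc(C(F)(F)F)cc1)Nc1ccc2nc(N3CCCCC3)ccc2c1` carries the change (a group of 6 heavy atoms (5 carbon, 1 nitrogen; one six-membered non-aromatic ring with 1 hetero atom) in place of a group of 8 heavy atoms (7 carbon, 1 nitrogen; 2 six-membered non-aromatic rings with 1 hetero atom each), on an aromatic carbon), placed on an aromatic carbon of a six-membered aromatic ring with 1 nitrogen, part of a fused or bridged system of two rings, next to the ring nitrogen.

For the measured compounds named here, the steps that bear on this change all concern the amine substituent at that position: a 3.4-fold lower number from compound 1 to compound 2 (0.54 log units; beyond the scatter), a 6.3-fold lower number from compound 1 to compound 3 (0.80 log units; beyond the scatter) and a 1.8-fold lower number from compound 2 to compound 3 (0.27 log units; within the scatter). They show that the shape of this group can move the number in this assay by a modest amount, with the bicyclic amine of compound 3 and the cyclopentyl amine of compound 2 sitting close together. Whether a smaller single ring follows compound 3 or falls back toward compound 1 is not decided by these three points. For compound 4 a step of a 2.1-fold higher number from compound 3 to compound 4 (0.32 log units; beyond the scatter) is therefore expected, most likely within or only just beyond the scatter, with a wide range. The estimate for compound 4 in this assay is 400 nM, between 100 nM and 1500 nM.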

Compound 4, half-maximal effective concentration: 110 nM
Compound 4: the middle estimate sits 3.6-fold (0.56 log units) above what was measured, within the range that was stated.
By their numbers in this assay, from the lowest: compounds 4, 3 and 2 (each within the scatter of the next, the first and the last beyond it); then compound 1.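

In this assay the step of a 1.7-fold lower number from compound 3 to compound 4 (0.24 log units; within the scatter) cannot separate piperidin-1-yl from the two-ring group, so at this position a single six-membered ring with its nitrogen on the aromatic carbon matches the larger group. Piperidin-1-yl does separate from both methylamino groups, with a 3.2-fold lower number from compound 2 to compound 4 (0.50 log units; beyond the scatter) and an 11-fold lower number from compound 1 to compound 4 (1.04 log units; beyond the scatter) as the steps, but this gives no clean split between ring-nitrogen and methylamino groups: compound 3 stays within the scatter of compound 2. No measurement at hand accounts for these differences.

Open, as far as these compounds go, is how pyrrolidin-1-yl or morpholin-4-yl would compare at this position, and whether a hydroxyl or a carboxylic acid on the piperidine ring would be tolerated. Also open, from the compounds shown here alone, is whether the same picture holds with another group in place of the trifluoromethyl.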